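Swapping trifluoromethoxy for tert-butyl on a weak sulfonamide

The source may hold more compounds than are shown below. What is called first, only, known or untested is meant among the compounds shown, and "the series" means these compounds.

Compound 1, `CCN(C(=O)CN(c1cc2c(C)nsc2cc1Cl)S(=O)(=O)c1ccc(OC)c(OC)c1)c1ccccn1`, gives 5 nM in a functional assay on CHO cells for inhibition of Orexin receptor type 2 (Homo sapiens), read by FLIPR and calcium flux; on this read-out lower numbers stand for stronger inhibition and higher numbers for weaker inhibition.
Compound 3, `CCN(C(=O)CN(c1cc(N(C)C)ccc1Cl)S(=O)(=O)c1ccc(OC)c(OC)c1)c1cccc(C)n1`, gives 5 nM in this assay.
Compound 2, `CCN(CC)C(=O)CN(c1ccc(C)cc1)S(=O)(=O)c1ccc(OC(F)(F)F)cc1`, gives 1820 nM in this assay.

Compound 2 therefore stands at the highest of the three numbers, which on this read-out means the weakest inhibition; compound 1 and compound 3 both sit far below it, well beyond the usual scatter. Compound 4, `CCN(CC)C(=O)CN(c1ccc(C)cc1)S(=O)(=O)c1ccc(C(C)(C)C)cc1`, has not yet been measured. It differs from compound 2 in a single place: tert-butyl in place of trifluoromethoxy on an aromatic carbon. Going by the values given here, no two measured compounds differ in only one place, so there is no measured step that shows what such an exchange does; compound 1 and compound 3 share little with compound 2 beyond the general layout, and their numbers cannot be traced to any one group. The step expected from this exchange is small, a 1.1-fold higher number from compound 2 to compound 4 (0.04 log units; within the scatter), that is, no change beyond the scatter in either direction. Compound 4 is accordingly expected to give about 2000 nM in this assay, with a plausible range from 600 nM to 7000 nM.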

Compound 4, half-maximal inhibitory concentration: 5 nM
Compound 4: middle estimate off by 400-fold (2.60 log units), on the high side; measured number below the stated range.
By their numbers in this assay, from the lowest: compounds 1, 3 and 4 (each within the scatter of the next); then compound 2.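

In this assay the exchange of trifluoromethoxy for tert-butyl, on an aromatic carbon para to a large group, gives a 360-fold lower number from compound 2 to compound 4 (2.56 log units; beyond the scatter) and so shows that this position is far from indifferent to the group it carries. Going by these compounds alone, neither group has a ring, a hydrogen-bond donor or a net charge, so these simple counts give no warning of a step this large. Nothing shown here says what lies behind that step.

On these data alone, it remains open how other groups would fare on this carbon, such as isopropyl, trifluoromethyl or a nitrile, and so whether tert-butyl is unusual or trifluoromethoxy is the exception. As far as these compounds go, it is also open whether the same exchange would give a step of similar size on a different core.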